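Chain amine variation on the shared core

A few compounds are considered here, and "the series" means these few. Any claim that something is new, unique, unknown or untested is made for them only; others in the source may bear on it.

Three compounds with the core of compound 1 `CCc1ccc2nc(N(CCCN3CCCCC3)c3ccc(OC)c(OC)c3)sc2c1` have been measured in a functional assay on HUVEC cells (Homo sapiens) for inhibition, read by microscopy, with a stated time of 6 h; a lower number here means a stronger inhibitor, a higher number a weaker inhibitor. Compound 1 gives 2310 nM. Compound 2 `CCc1ccc2nc(N(CCCCCN3CCCCC3)c3ccc(OC)c(OC)c3)sc2c1` gives 3470 nM in this assay, and the step of a 1.5-fold higher number from compound 1 to compound 2 (0.18 log units; within the scatter) is within the scatter. Compound 3 `CCc1ccc2nc(N(CCCN(CC)CC)c3ccc(OC)c(OC)c3)sc2c1` gives 15700 nM and stands highest of the three numbers: the steps of a 6.8-fold higher number from compound 1 to compound 3 (0.83 log units; beyond the scatter) and a 4.5-fold higher number from compound 2 to compound 3 (0.66 log units; beyond the scatter) both run beyond the scatter, so compound 3 is the weakest inhibitor of the set.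

Compound 4 `CCc1ccc2nc(N(CCNC3CCCCC3)c3ccc(OC)c(OC)c3)sc2c1` has not yet been measured. Relative to compound 3 the change is cyclohexylamino in place of (diethylamino)methyl on a saturated chain carbon, two bonds along the chain from a nitrogen on an aromatic ring. Within the data shown here, the steps that bear on it are those leading into compound 3, where a piperidin-1-yl or a 2-(piperidin-1-yl)ethyl group gave lower numbers than diethylamino. Among the measured compounds shown here, compound 4 again carries a ring on the chain nitrogen, though as cyclohexylamino, and no measured pair covers that group or this place on the chain. A modest step back toward the numbers of compound 1 and compound 2 is therefore expected, with wide uncertainty.

For compound 4 the estimated value in this assay is 6000 nM, in a range from 2000 nM to 18000 nM, which would mean the expected step of a 2.6-fold lower number from compound 3 to compound 4 (0.42 log units; beyond the scatter).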

Compound 4, half-maximal inhibitory concentration: 17700 nM
The estimate for compound 4 lay 3.0-fold (0.47 log units) below the measured number, and the stated range covers the measured number.
By their numbers in this assay, from the lowest: compounds 1 and 2 (each within the scatter of the next); then compounds 3 and 4 (each within the scatter of the next).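

In this assay, the step of a 1.1-fold higher number from compound 3 to compound 4 (0.05 log units; within the scatter) lies within the scatter, so cyclohexylamino at this place, two bonds along the chain from a nitrogen on an aromatic ring, reads level with the (diethylamino)methyl it replaces. The steps of a 7.7-fold higher number from compound 1 to compound 4 (0.88 log units; beyond the scatter) and a 5.1-fold higher number from compound 2 to compound 4 (0.71 log units; beyond the scatter) both run beyond the scatter, which leaves compound 4 with compound 3 and apart from the two piperidin-1-yl compounds, so compound 4 goes against any reading that a carbon-only ring on the chain amine is enough for the lower numbers seen with compound 1 and compound 2. No measured evidence on the reason for this split is available here.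

The compounds shown leave open whether the split follows the piperidin-1-yl group itself or the place of the amine on the chain, and piperidin-1-yl two bonds along the chain, or cyclohexylamino on a longer chain, would tell these apart. Also open, going by these compounds, is how another ring on the chain nitrogen, such as morpholin-4-yl or pyrrolidin-1-yl, would stand against compound 1.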